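Carbonyl substituent variation in the series

The source may report more compounds than this note shows. Statements on the series, on what has been measured and on what is new or still open speak of the compounds shown alone.

Among the compounds with values here, compound 3 `CC1=C(C(=O)NC(C)C)C(c2ccoc2)NC(=O)N1` gives 1% in an assay on membranes from CHO cells for displacement of a labelled ligand from adenosine receptor A1 (Homo sapiens), read by scintillation counting, with a stated time of 60 min, tested at 1 uM (on this read-out higher numbers stand for more inhibition at the one concentration tested (going by the name of the read-out) and lower numbers for less inhibition), the lowest of the three numbers so far; compound 1 `COC(=O)C1=C(C)NC(=O)NC1c1ccoc1` stands nearest with 8% (within the scatter), and compound 2 `CC1=C(C(=O)OCc2ccccc2)C(c2ccoc2)NC(=O)N1` furthest with 41% (beyond the scatter). Compound 4 `CCC(CC)OC(=O)C1=C(C)NC(=O)NC1c1ccoc1` differs from compound 3 by (pentan-3-yl)oxy in place of isopropylamino on a carbonyl carbon. Within the data shown here, two measured steps bear on this. The swap at the carbonyl carbon, a number 7 percentage points lower from compound 1 to compound 3 (within the scatter), stayed within the scatter, so that part of the change is expected to count for little. Enlarging the group on the oxygen, a number 33 percentage points higher from compound 1 to compound 2 (beyond the scatter), was large, and (pentan-3-yl)oxy is larger than methoxy without carrying a phenyl. A modest upward step a number 14 percentage points higher from compound 3 to compound 4 (beyond the scatter) is therefore expected in this assay. Compound 4 is estimated at 15%, between 0% and 40%.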

Compound 4, a percentage reported as inhibition, at one concentration (the size of the read-out at that concentration, not a potency): 17%
Estimate against measurement, compound 4: 2 percentage points below; measured number inside the range.
By their numbers in this assay, from the lowest: compounds 3, 1 and 4 (each within the scatter of the next, the first and the last beyond it); then compound 2.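

On the oxygen next to a carbonyl group, pentan-3-yl in place of methyl gives a number 9 percentage points higher from compound 1 to compound 4 (within the scatter) and stays within the scatter, whereas pentan-3-yl in place of benzyl gives a number 24 percentage points lower from compound 2 to compound 4 (beyond the scatter) in this assay and so does not match benzyl. On the carbonyl carbon, (pentan-3-yl)oxy in place of isopropylamino gives a number 16 percentage points higher from compound 3 to compound 4 (beyond the scatter) and lies beyond the scatter, while a number 7 percentage points lower from compound 1 to compound 3 (within the scatter) stayed within it. Nothing available explains these steps.

Going by these compounds, a phenethyl group on that oxygen remains open. So does a carboxylic acid or a benzylamino group on the carbonyl carbon.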